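The source may hold more compounds than are shown below. What is called first, only, known or untested is meant among the compounds shown, and "the series" means these compounds.

Measured so far in a functional assay on MGC-803 cells (Homo sapiens) for inhibition, read by MTT assay, with a stated time of 72 h; a higher number here means a weaker inhibitor, a lower number a stronger inhibitor:
- compound 1, `O=C(CSc1nc(Nc2ccccc2)c2ccccc2n1)Nc1cccc([N+](=O)[O-])c1`: 28100 nM
- compound 2, `C=CC(=O)Nc1cccc(NC(=O)CSc2nc(Nc3ccccc3)c3ccccc3n2)c1`: 7310 nM

Compound 2 stands lowest of the two, with compound 1 the nearer neighbour by a 3.8-fold lower number from compound 1 to compound 2 (0.58 log units; beyond the scatter). Compound 3, `C=CC(=O)Nc1cccc(NC(=O)CSc2nc(Nc3cccc([N+](=O)[O-])c3)c3ccccc3n2)c1`, differs from compound 2 by nitro in place of hydrogen on an aromatic carbon. Going by the values given here, no measured step bears directly on this change: the single step from compound 1 to compound 2 swapped a nitro on the other aromatic ring, and gave a modest result. Compound 3 is therefore expected to stay near compound 2, with a step of a 1.1-fold lower number from compound 2 to compound 3 (0.05 log units; within the scatter), none beyond the scatter. The estimate for compound 3 in this assay is 6500 nM, ranging from 2200 nM to 20000 nM.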

Compound 3, half-maximal inhibitory concentration: > 50000 nM
Compound 3 was reported as a limit; the forecaster's own chance of this, stated with the estimate: 5%; middle value at least 7.6-fold (0.88 log units) from the limit.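

In this assay, replacing phenyl with 3-nitrophenyl on the anilino nitrogen gives an at least 6.8-fold higher number from compound 2 to compound 3 (0.83 log units; beyond the scatter). Going by these compounds alone, compound 1 and compound 2 differ only on the other aromatic ring, so this is the first sign that the anilino ring responds to substitution, and here a nitro group there weakens inhibition. The reading for compound 3 is a limit and not a number: the limit of > 50000 nM in this assay, at which 1 of the 3 values shown sits.

The compounds shown leave open whether an amine or a methoxy group in this same place would bring a similar loss. They also leave open whether nitro is tolerated elsewhere on the anilino ring.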